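Swapping a dimethylphenyl for a cyanophenyl on the sulfonyl

A few compounds are considered here, and "the series" means these few. Any claim that something is new, unique, unknown or untested is made for them only; others in the source may bear on it.

Of the compounds shown here, three sharing one core have been measured in an ADME assay on microsomes from liver (Homo sapiens) for metabolic stability, tested at 2.5 uM; on this read-out lower numbers stand for slow clearance and higher numbers for fast clearance. Compound 1 `N#Cc1cccc(S(=O)(=O)c2cnc3cc(F)ccc3c2-c2ccccc2F)c1` gives 1.39 mL/min. Compound 2 `Cc1ccc(S(=O)(=O)c2cnc3cc(F)ccc3c2-c2cccc(F)c2)cc1F` gives 0.41 mL/min. Compound 3 `Cc1ccc(S(=O)(=O)c2cnc3cc(F)ccc3c2-c2cccc(F)c2)cc1C` gives 3.71 mL/min, the highest of the three numbers, above compound 1 by a margin beyond the scatter and furthest from compound 2. Going by the values given here, the only single-point step among the measured compounds is a 9.0-fold higher number from compound 2 to compound 3 (0.96 log units; beyond the scatter), and it concerns a different part of the molecule from the one altered in compound 4.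

Compound 4 `N#Cc1cccc(S(=O)(=O)c2cnc3cc(F)ccc3c2-c2cccc(F)c2)c1` differs from compound 3 by 3-cyanophenyl in place of 3,4-dimethylphenyl on a sulfonyl sulfur. Among the compounds with values here, no measured step bears directly on this change. The nearest guide is compound 1, which carries the same 3-cyanophenyl on the sulfonyl sulfur and in this assay shows a lower number than compound 3. Compound 4 is therefore expected to come out below compound 3. The expected step is a 3.1-fold lower number from compound 3 to compound 4 (0.49 log units; beyond the scatter). This rests on compound 1 giving 1.39 mL/min in this assay, while the remaining difference between compound 1 and compound 4 is not covered by any measured pair. The estimate for compound 4 in this assay is 1.2 mL/min, with a range from 0.5 mL/min to 3 mL/min.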

Compound 4, intrinsic clearance in a liver preparation (reported as CLH), per the amount of preparation that the assay uses: 0.78 mL/min
The estimate for compound 4 lay 1.5-fold (0.19 log units) above the measured number, within the range that was stated.
By their numbers in this assay, from the lowest: compounds 2, 4 and 1 (each within the scatter of the next, the first and the last beyond it); then compound 3.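

In this assay, going by these compounds alone, the step of a 4.8-fold lower number from compound 3 to compound 4 (0.68 log units; beyond the scatter) lies beyond the scatter and gives the first direct reading of 3-cyanophenyl in place of 3,4-dimethylphenyl on a sulfonyl sulfur, with the rest of the molecule held fixed. Against 3-fluoro-4-methylphenyl at the same place, the step of a 1.9-fold higher number from compound 2 to compound 4 (0.28 log units; within the scatter) lies within the scatter, so of the three groups seen on the sulfonyl sulfur, only 3,4-dimethylphenyl stands apart on this read-out. The other new comparison, a 1.8-fold lower number from compound 1 to compound 4 (0.25 log units; within the scatter), also lies within the scatter, so 3-fluorophenyl in place of 2-fluorophenyl on an aromatic carbon does not separate these two compounds when 3-cyanophenyl sits on the sulfonyl sulfur.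

Nothing available here speaks to what lies behind these differences. On these data alone, what a 3-methoxyphenyl or a 3-aminophenyl on the sulfonyl sulfur would give remains open, as does whether the gap between 3,4-dimethylphenyl and 3-cyanophenyl would hold with 2-fluorophenyl in place of 3-fluorophenyl.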